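The compounds below may be only part of what the source reports. "The series", "measured", "known", "first", "only" and "open" are said of these compounds alone.

Compound 3 `COc1cc2ncnc(Nc3ccc(Br)cc3)c2cc1OCCCCC(=O)Nc1ccc(S(N)(=O)=O)cc1` stands lowest of the three numbers in a functional assay on A-431 cells (Homo sapiens) for antiproliferative activity, read by MTT assay, with a stated time of 72 h (a lower number here means a stronger inhibitor, a higher number a weaker inhibitor), where compound 3 gives 6570 nM. Compound 1 `COc1cc2ncnc(Nc3cccc(Cl)c3)c2cc1OCCCCC(=O)Nc1ccc(S(N)(=O)=O)cc1` gives 30400 nM and compound 2 `COc1cc2ncnc(Nc3cccc(F)c3)c2cc1OCCCCC(=O)Nc1ccc(S(N)(=O)=O)cc1` gives 29900 nM; between them, a 1.0-fold lower number from compound 1 to compound 2 (0.01 log units; within the scatter), so these two cannot be told apart. The two steps that swap the aryl on the nitrogen of the shared core, a 4.6-fold lower number from compound 1 to compound 3 (0.67 log units; beyond the scatter) and a 4.6-fold lower number from compound 2 to compound 3 (0.66 log units; beyond the scatter), are the only ones that bear on compound 4 `COc1cc2ncnc(Nc3cccc(Cl)c3F)c2cc1OCCCCC(=O)Nc1ccc(S(N)(=O)=O)cc1`. Compound 4 differs from compound 3 by 3-chloro-2-fluorophenyl in place of 4-bromophenyl on a nitrogen on an aromatic ring. Within the data shown here, the 4-bromophenyl that went with the lower number of compound 3 is given up, and a 3-chlorophenyl pattern of the kind seen in compound 1 returns, now carrying a fluorine as well; no measured compound has this pairing of halogens, so the fluorine's contribution is unknown. The working expectation for compound 4 is therefore a step back up in this assay, a 2.3-fold higher number from compound 3 to compound 4 (0.36 log units; beyond the scatter), undoing much but not necessarily all of the gain seen in compound 3. Compound 4 is accordingly estimated at 15000 nM, with a range from 4000 nM to 50000 nM.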

Compound 4, half-maximal inhibitory concentration: 5560 nM
Compound 4: the middle estimate sits 2.7-fold (0.43 log units) above what was measured, within the range that was stated.
By their numbers in this assay, from the lowest: compounds 4 and 3 (each within the scatter of the next); then compounds 2 and 1 (each within the scatter of the next).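

In this assay, a fluorine added to the aryl on the nitrogen is a step beyond the scatter, a 5.5-fold lower number from compound 1 to compound 4 (0.74 log units; beyond the scatter), and 3-chloro-2-fluorophenyl in place of 3-fluorophenyl gives a similar one, a 5.4-fold lower number from compound 2 to compound 4 (0.73 log units; beyond the scatter), although the single-halogen compound 1 and compound 2 could not be told apart. The 4-bromophenyl is therefore not alone among these aryl groups in reaching this level, since a 1.2-fold lower number from compound 3 to compound 4 (0.07 log units; within the scatter) leaves the two groups indistinguishable here. No supporting data bear on what lies behind these steps.

The compounds shown leave open whether fluoro in place of hydrogen on the 4-bromophenyl would give a comparable step. On these data alone, how an unsubstituted phenyl on the same nitrogen, or a longer chain in the linker of compound 4, would read in this assay also remains open.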